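This account rests on a few compounds, and the source may have more. Where it says the series, first, only, none or still open, it means among the compounds named here.

Measured in a functional assay (aorta) with Oryctolagus cuniculus as the target; on this read-out higher numbers stand for weaker binding and lower numbers for tighter binding:

Compound 1 `Fc1ccc(OCCCN2CCC(C(c3ccc(F)cc3)c3ccc(F)cc3)CC2)cc1`: 1.26 nM
Compound 2 `Fc1ccc(C(c2ccc(F)cc2)C2CCN(CCCOc3ccc(Cl)cc3)CC2)cc1`: 2 nM

Compound 2, at 2 nM, stands within the scatter of compound 1, so these two numbers cannot be ranked. Compound 3 `Nc1ccc(OCCCN2CCC(C(c3ccc(F)cc3)c3ccc(F)cc3)CC2)cc1` is not yet measured. It differs from compound 2 by amino in place of chloro on an aromatic carbon, with amino in place of chloro on an aromatic carbon, para to a large group. Within the data shown here, only one measured step bears on this change: a 1.6-fold higher number from compound 1 to compound 2 (0.20 log units; within the scatter). Among the measured compounds shown here, that step exchanges fluoro for chloro, so it says little about amino, and no amino compound has been measured. In this assay, no step beyond the scatter is therefore expected, with only a slight lean towards a higher number. The estimated step is a 1.5-fold higher number from compound 2 to compound 3 (0.18 log units; within the scatter). For compound 3 the expected value is 3 nM, with an estimated range of 0.8 nM to 12 nM.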

Compound 3, dissociation constant: 31.6 nM
The estimate for compound 3 lay 11-fold (1.02 log units) below the measured number, outside the stated range (above it).
By their numbers in this assay, from the lowest: compounds 1 and 2 (each within the scatter of the next); then compound 3.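

The earlier pair showed only that fluoro and chloro on this aromatic carbon, para to a large group, could not be ranked in this assay. Amino is the first group here to stand apart from them, with a 16-fold higher number from compound 2 to compound 3 (1.20 log units; beyond the scatter) and a 25-fold higher number from compound 1 to compound 3 (1.40 log units; beyond the scatter). So the exchange of a single heavy atom at this place, which brings in a hydrogen-bond donor and acceptor where chloro and fluoro count none, goes with clearly weaker binding, and nothing given here explains that step.

As far as these compounds go, whether this weaker binding is particular to amino stays open, and a hydroxy, methoxy or acetamido group at the same place could test that. From the compounds shown here alone, it is also open whether a dimethylamino group would follow amino or stay with the halogens.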